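Replacing 5-cyanopyrazin-2-yl with 5-methyl-1,3,4-oxadiazol-2-yl

The compounds below may be only part of what the source reports. "The series", "measured", "known", "first", "only" and "open" are said of these compounds alone.

In an ADME assay on the whole organism (Rattus norvegicus) for pharmacokinetics, at a dose of 1 mg/kg by the intravenous route (on this read-out lower numbers stand for lower exposure and higher numbers for higher exposure at the dose given), compound 2 (`N#Cc1cnc(N2CCC(C(=O)N3N=CC[C@H]3c3cc(F)cc(F)c3)CC2)cn1`) gives 400 ng.h/mL. Compound 1 (`Cc1nnc(N2CCC(C(=O)N3N=CC[C@H]3c3ccccc3)CC2)o1`) gives 800 ng.h/mL, and compound 3 (`O=C(c1cn[nH]c1)N1CCC(C(=O)N2N=CCC2c2ccccc2)CC1`) gives 360 ng.h/mL. Compound 2 therefore stands within the usual scatter of both other compounds, and the three numbers do not separate from one another.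

Compound 4 (`Cc1nnc(N2CCC(C(=O)N3N=CC[C@H]3c3cc(F)cc(F)c3)CC2)o1`) has not yet been measured. It carries 5-methyl-1,3,4-oxadiazol-2-yl in place of 5-cyanopyrazin-2-yl on an amine nitrogen in a ring. Among the compounds with values here, no two measured compounds differ in one place alone, so no direct step is available as a guide. The nearest evidence is compound 1, which bears the same 5-methyl-1,3,4-oxadiazol-2-yl group and gives 800 ng.h/mL. On that basis, a small rise that stays within the scatter is expected in this assay, estimated as a 1.5-fold higher number from compound 2 to compound 4 (0.18 log units; within the scatter). For compound 4 the estimated value is 600 ng.h/mL, with an expected range of 260 ng.h/mL to 1300 ng.h/mL.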

Compound 4, area under the concentration-time curve: 1300 ng.h/mL
Compound 4: the middle estimate sits 2.2-fold (0.34 log units) below what was measured; measured number inside the range.
By their numbers in this assay, from the lowest: compounds 3, 2, 1 and 4 (each within the scatter of the next, the first and the last beyond it).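

In this assay the exchange of 5-cyanopyrazin-2-yl for 5-methyl-1,3,4-oxadiazol-2-yl on an amine nitrogen in a ring gives a 3.3-fold higher number from compound 2 to compound 4 (0.51 log units; beyond the scatter) and so provides a single-place comparison at this position, one that lies beyond the scatter. By contrast, 3,5-difluorophenyl in place of phenyl on a saturated ring carbon gives a 1.6-fold higher number from compound 1 to compound 4 (0.21 log units; within the scatter) with 5-methyl-1,3,4-oxadiazol-2-yl held constant, which is within the scatter and shows no readable change. Nothing available accounts for the step at the amine nitrogen.

The compounds shown leave open whether the same exchange would give a step of similar size with phenyl in place of 3,5-difluorophenyl. They also leave open how an acetyl group or a ring carrying a carboxylic acid on that amine nitrogen would read in this assay against 5-methyl-1,3,4-oxadiazol-2-yl.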